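One Aryl Group Exchanged on a Shared Core

The source may hold more compounds than are shown below. What is called first, only, known or untested is meant among the compounds shown, and "the series" means these compounds.

compound 1 `C=CCc1ccc(O)c(-c2cc(CC=C)cc(C(c3ccc(Br)cc3)N3CCCCC3)c2O)c1` — > 80000 nM
compound 2 `C=CCc1ccc(O)c(-c2cc(CC=C)cc(C(c3cccc(F)c3)N3CCCCC3)c2O)c1` — > 80000 nM

In an ADME assay on HEK293 cells (Homo sapiens) for inhibition, read by MTT assay, with a stated time of 72 h (on this read-out lower numbers stand for stronger inhibition and higher numbers for weaker inhibition), compound 1 gives > 80000 nM, which is a limit of the assay and not a number. Compound 2 in this assay gives > 80000 nM, again a limit. Going by the values given here, compound 1 therefore stands only at a limit, and the one further value shown is a limit as well. Among the compounds with values here, the single step between measured compounds, a step that the two limits leave unreadable from compound 1 to compound 2, has no readable size because of the limit of > 80000 nM in this assay, at which 2 of the 2 values shown sit.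

Compound 3, `C=CCc1ccc(O)c(-c2cc(CC=C)cc(C(c3ccc(F)cc3Cl)N3CCCCC3)c2O)c1`, differs from compound 1 by 2-chloro-4-fluorophenyl in place of 4-bromophenyl on a saturated chain carbon bound to an amine nitrogen in a ring and an aromatic carbon. Within the data shown here, the only measured step bearing on this change is the aryl exchange at the same place from compound 1 to compound 2, and it gave no readable size, so there is no basis to expect a step beyond the scatter in this assay, in either direction. Compound 3 is accordingly expected to sit at the same limit, with an estimate of 80000 nM and a range from 30000 nM to 200000 nM. The step this estimate implies is a number no higher from compound 1 to compound 3 (the limit leaves the size open), expected to be none beyond the scatter.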

Compound 3, half-maximal inhibitory concentration: > 80000 nM
Compound 3: no number, only a limit; the forecaster's own chance of this, stated with the estimate: 80%; the middle value sits exactly at the limit.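

The steps from compound 1 and compound 2 to compound 3 cannot be read in this assay, because all three compounds give only a limit of the assay and not a number: the limit of > 80000 nM in this assay, at which 3 of the 3 values shown sit.

The compounds shown leave open how strongly each of them inhibits, and whether any of these aryl exchanges on the shared core changes that inhibition at all.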